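This account rests on a few compounds, and the source may have more. Where it says the series, first, only, none or still open, it means among the compounds named here.

Measured compounds:
compound 1 `NC1=NC2(CCOCC2)N(OCCCOc2ccccc2Cl)C(N)=N1` gives 1750 nM;
compound 2 `NC1=NC2(CCOCC2)N(OCCCOc2cccc(Br)c2)C(N)=N1` gives 320 nM;
compound 3 `NC1=NC2(CCSCC2)N(OCCCOc2ccccc2Cl)C(N)=N1` gives 80 nM.

These three values come from a functional assay on HepG2 cells (Homo sapiens) for antiproliferative activity, read by MTT assay, with a stated time of 72 h; on this read-out lower numbers stand for stronger inhibition and higher numbers for weaker inhibition. Compound 1 and compound 2 share a core and differ in one place, by 3-bromophenyl in place of 2-chlorophenyl on an oxygen on a saturated carbon. That change brought a 5.5-fold lower number from compound 1 to compound 2 (0.74 log units; beyond the scatter). Compound 3 carries a different core; the difference between the core of compound 3 and the core of compound 1 is not broken down here, but compound 3 gives the lowest of the three numbers, below compound 2 and far below compound 1.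

Compound 4 `NC1=NC2(CCSCC2)N(OCCCOc2cccc(Br)c2)C(N)=N1` has not yet been measured in this assay. It stands to compound 3 as compound 2 stands to compound 1: it differs from compound 3 by 3-bromophenyl in place of 2-chlorophenyl on an oxygen on a saturated carbon, and the place of the change is the same word for word in both pairs, so it is the same change made on the second core. If that change acts alike on both cores, compound 4 is expected to show a step of about a 4.0-fold lower number from compound 3 to compound 4 (0.60 log units; beyond the scatter), resting on compound 1 and compound 2 where the same change gave a 5.5-fold lower number from compound 1 to compound 2 (0.74 log units; beyond the scatter). On that basis compound 4 is estimated at 20 nM, most likely between 6 nM and 65 nM.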

Compound 4, half-maximal inhibitory concentration: 90 nM
The estimate for compound 4 lay 4.5-fold (0.65 log units) below the measured number; the measured number lies above the stated range.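

In this assay, 3-bromophenyl in place of 2-chlorophenyl on the second core brought a 1.1-fold higher number from compound 3 to compound 4 (0.05 log units; within the scatter), so compound 3 and compound 4 cannot be told apart. Set beside the earlier step on the first core, the change did not carry over with the same size: the same change on two cores in this assay, a 5.5-fold lower number (0.74 log units; beyond the scatter) from compound 1 to compound 2 and a 1.1-fold higher number (0.05 log units; within the scatter) from compound 3 to compound 4, 6.2-fold (0.79 log units) apart, beyond the scatter of two such steps. This shows that, in these two pairs, the outcome of the change depends on the core it is made on, but it does not show why, and two pairs cannot tell how the change would behave on any further core.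

The compounds shown leave open whether the halogen or its place on the ring matters more, which 3-chlorophenyl or 2-bromophenyl on both cores could help to separate. They also leave open how the two cores would respond to a different group on the oxygen, such as a pyridine ring, or to a longer chain.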